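The source may report more compounds than this note shows. Statements on the series, on what has been measured and on what is new or still open speak of the compounds shown alone.

Measured so far:
- compound 1, `O=C(NCc1cc(C(F)(F)F)cc(C(F)(F)F)c1)c1cnc2ccccc2c1-c1ccccc1`: > 1000 nM
- compound 2, `CN(Cc1cc(C(F)(F)F)cc(C(F)(F)F)c1)C(=O)c1c(CO)nc2ccccc2c1-c1ccccc1`: 16 nM

Both were tested in an in vitro assay on UC11MG cells for binding affinity to Substance-P receptor (Homo sapiens), read by radioligand binding; on this read-out higher numbers stand for weaker inhibition and lower numbers for stronger inhibition. For compound 1 the result is a limit of the assay rather than a number, > 1000 nM, so its true value is only known to lie beyond that point; (the limit of > 1000 nM in this assay, at which 1 of the 2 values shown sits). Compound 2 gives 16 nM in this assay. Within the data shown here, compound 2 differs from compound 1 in two places at once, so its value shows only that a compound of this core can bind strongly, not which change matters.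

Compound 3, `CN(Cc1ccccc1)Cc1nc2ccccc2c(-c2ccccc2)c1C(=O)NCc1cc(C(F)(F)F)cc(C(F)(F)F)c1`, is not yet measured. It keeps the amide of compound 1 unchanged and carries one change on the core: (benzyl(methyl)amino)methyl in place of hydrogen on an aromatic carbon. Since compound 1 offers only a limit, the step to compound 3 cannot be anchored to a number. The expectation for the step from compound 1 to compound 3 in this assay is an improvement of an at least 2.5-fold lower number from compound 1 to compound 3 (0.39 log units; beyond the scatter), with wide uncertainty. Compound 3 is therefore estimated at 400 nM, in a range from 60 nM to 3000 nM.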

Compound 3, half-maximal inhibitory concentration: 180 nM
Estimate against measurement, compound 3: 2.2-fold (0.35 log units) above; the range from low to high includes it.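

Placing (benzyl(methyl)amino)methyl in place of hydrogen on an aromatic carbon next to the ring nitrogen, with the amide left as it is in compound 1, gives in this assay an at least 5.5-fold lower number from compound 1 to compound 3 (0.74 log units; beyond the scatter). Among these compounds, compound 1 stands at a limit of the assay rather than a number, and the full size of this step stays unknown because of that limit: the limit of > 1000 nM in this assay, at which 1 of the 3 values shown sits. Compound 2 differs from compound 1 in two places at once, whereas compound 3 differs in one, so this is the first result that ties a gain in binding to this position alone and shows that the amide hydrogen can stay while a group of this size sits there.

Which part of the new group carries the gain remains open, since a plain methyl or a dimethylaminomethyl group on the same carbon would separate the amine from the benzyl ring. As far as these compounds go, it is also open whether a methyl on the amide nitrogen of compound 3 would change its value, as that change is not seen on its own here.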